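The source may hold more compounds than are shown below. What is called first, only, known or untested is meant among the compounds shown, and "the series" means these compounds.

Of the compounds shown here, three built on one shared core have been tested in an assay on HEK293-TREx cells for antagonist activity at transient receptor potential cation channel subfamily A member 1 (Homo sapiens), read by fluorescence and calcium flux, with a stated time of 72 h; a higher number here means a weaker inhibitor, a lower number a stronger inhibitor. Compound 1, `Fc1ccc(Oc2ncnc3[nH]ccc23)c(F)c1`, gives 710 nM in this assay. Compound 2, `Fc1cccc(Oc2ncnc3[nH]ccc23)c1F`, gives 2700 nM in this assay. Compound 3, `Fc1cccc(Oc2ncnc3[nH]ccc23)c1`, is recorded only as a limit of this assay, > 32000 nM, so no number is known for it. Of the two compounds with a number, compound 1 has the lower one, and its nearest neighbour is compound 2.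

Compound 3 and compound 2 differ in one place: fluoro in place of hydrogen on an aromatic carbon. That change brought an at least 11-fold lower number from compound 3 to compound 2 (1.07 log units; beyond the scatter), and its size can only be bounded because compound 3 sits at the limit of > 32000 nM in this assay, at which 1 of the 3 values shown sits. How the core of compound 1 differs from that of compound 3 is not broken down here.

Compound 4, `Fc1cc(F)c(Oc2ncnc3[nH]ccc23)c(F)c1`, has not yet been measured. It differs from compound 1 in one place: fluoro in place of hydrogen on an aromatic carbon. Going by the values given here, this is the same kind of change as the one from compound 3 to compound 2, but not the same: there the fluoro entered ortho to a fluoro group and ortho to a large group, while here it enters ortho to a large group and meta to two fluoro groups. The earlier step was large, yet a smaller step is expected here, since compound 1 already gives 710 nM and starts well inside the measurable range. The step expected is a 2.4-fold lower number from compound 1 to compound 4 (0.37 log units; beyond the scatter). Compound 4 is expected to give about 300 nM in this assay, most likely somewhere from 100 nM to 1000 nM.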

Compound 4, half-maximal inhibitory concentration: > 32000 nM
Compound 4 ended at the assay's limit (the forecaster's own chance of this, stated with the estimate: 5%); middle value at least 100-fold (2.02 log units) away from the limit.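

In this assay, putting fluoro in place of hydrogen on an aromatic carbon brought an at least 45-fold higher number from compound 1 to compound 4 (1.65 log units; beyond the scatter). Going by these compounds alone, the size of this step is only a bound, and compound 4 stands at a limit of the assay rather than at a number: the limit of > 32000 nM in this assay, at which 2 of the 4 values shown sit. Even so, the same kind of change clearly does not carry over from one core to another, since the two steps run in opposite directions and lie far apart: the same change on two cores in this assay, an at least 11-fold lower number (1.07 log units; beyond the scatter) from compound 3 to compound 2 and an at least 45-fold higher number (1.65 log units; beyond the scatter) from compound 1 to compound 4, at least 530-fold (2.72 log units) apart, beyond the scatter of two such steps These two steps do not show why the results part ways, and with only one pair on each side they give no rule for predicting the change on any further core.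

The compounds shown leave open whether a group other than fluoro, such as chloro, methyl or methoxy, would give a measurable number when placed ortho to a large group and meta to two fluoro groups. They also leave open how an amine or a longer chain on the shared core would read in this assay, and whether such a group would change what a further fluoro does on the aromatic ring.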